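Shifting a Trifluoromethyl Group on a Phenyl Ring

The compounds below may be only part of what the source reports. "The series", "measured", "known", "first", "only" and "open" are said of these compounds alone.

Two compounds have been measured in a functional assay on HeLa cells (Homo sapiens) for antiproliferative activity, read by MTT assay, with a stated time of 48 h; a higher number here means a weaker inhibitor, a lower number a stronger inhibitor:

Compound 1, `COc1ccc(-c2cn3cc(C4=CCN(S(=O)(=O)CCc5ccccc5)CC4)ccc3n2)cc1OC`: 8980 nM
Compound 2, `COc1ccc(-c2cn3cc(C4=CCN(C(=O)c5ccccc5C(F)(F)F)CC4)ccc3n2)cc1OC`: 7950 nM

Among the compounds with values here, compound 2 has the lowest of the two numbers, but the only measured step, a 1.1-fold lower number from compound 1 to compound 2 (0.05 log units; within the scatter), lies within the scatter, so the two compounds cannot be ranked against each other.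

Compound 3, `COc1ccc(-c2cn3cc(C4=CCN(C(=O)c5cccc(C(F)(F)F)c5)CC4)ccc3n2)cc1OC`, differs from compound 2 in one place: 3-(trifluoromethyl)phenyl in place of 2-(trifluoromethyl)phenyl on a carbonyl carbon. Within the data shown here, no measured step moves a group from one position of the phenyl ring to another; the single step available exchanged the whole group on the ring nitrogen and left the number essentially unchanged. Nothing in the data therefore points to a shift in either direction, and a step of a 1.0-fold higher number from compound 2 to compound 3 (0.00 log units; within the scatter) is expected, meaning no change beyond the scatter. Compound 3 is estimated at 8000 nM, with a likely range from 3000 nM to 20000 nM.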

Compound 3, half-maximal inhibitory concentration: 4860 nM
For compound 3 the middle estimate is 1.6-fold (0.22 log units) above the measured one, within the range that was stated.
By their numbers in this assay, from the lowest: compounds 3, 2 and 1 (each within the scatter of the next).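

Within the data shown here, this is the first measured move of the trifluoromethyl group around the phenyl ring: in this assay, 3-(trifluoromethyl)phenyl in place of 2-(trifluoromethyl)phenyl on the carbonyl carbon gives a 1.6-fold lower number from compound 2 to compound 3 (0.21 log units; within the scatter) and so does not separate the two placements. The exchange of the whole group on the ring nitrogen, read with the new compound, gives a 1.8-fold lower number from compound 1 to compound 3 (0.27 log units; within the scatter) and so leaves (3-(trifluoromethyl)phenyl)carbonyl and phenethylsulfonyl unranked as well. No further data are available to explain these small differences.

Still open, going by these compounds, is whether an amine or a carboxylic acid in place of the trifluoromethyl group, or a longer chain in place of the phenyl ring, would move the number beyond the scatter. On these data alone, all three compounds share one core, so the effect of changes to that core also remains unknown.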